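The compounds below may be only part of what the source reports. "The series", "measured", "known", "first", "only" and "open" are said of these compounds alone.

Of the compounds shown here, three have been measured in a functional assay on HEK293 cells for agonist activity at D(4) dopamine receptor (Homo sapiens), read by FLIPR; on this read-out lower numbers stand for an effect already at smaller amounts and higher numbers for an effect only at larger amounts of compound. Compound 1 `COc1ccccc1C1CCN(CC(=O)Nc2cccc(C)c2)CC1` gives 420 nM in this assay, the highest of the three numbers. Compound 2 `O=C(CN1CCC(c2cccc[n+]2[O-])CC1)Nc1cccc(F)c1` gives 160 nM, and compound 3 `Cc1cc(NC(=O)CN2CCC(c3cccc[n+]3[O-])CC2)ccc1F` gives 18 nM. Compounds 2 and 3 differ only at the amide-type nitrogen, and that single change gave an 8.9-fold lower number from compound 2 to compound 3 (0.95 log units; beyond the scatter).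

Compound 4 `Cc1cccc(NC(=O)CN2CCC(c3ccc(O)cn3)CC2)c1` has not yet been measured. Compared with compound 1 it carries 5-hydroxypyridin-2-yl in place of 2-methoxyphenyl on a saturated ring carbon. Within the data shown here, no measured step covers this change: compounds 2 and 3 carry a different ring at the same saturated ring carbon and also different groups on the amide-type nitrogen, so they show only that a ring other than 2-methoxyphenyl at that position can go with lower numbers than compound 1, without telling how 5-hydroxypyridin-2-yl itself behaves. The expectation therefore leans only gently toward a lower number, with wide uncertainty. For compound 4 the estimate in this assay is 200 nM, with a range from 50 nM to 800 nM, which would mean an expected 2.1-fold lower number from compound 1 to compound 4 (0.32 log units; beyond the scatter).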

Compound 4, half-maximal effective concentration: 3.8 nM
Compound 4: the middle estimate sits 53-fold (1.72 log units) above what was measured, outside the stated range (below it).
By their numbers in this assay, from the lowest: compound 4; then compound 3; then compound 2; then compound 1.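

In this assay, putting 5-hydroxypyridin-2-yl in place of 2-methoxyphenyl on the saturated ring carbon gives a 110-fold lower number from compound 1 to compound 4 (2.04 log units; beyond the scatter) with the rest of compound 1 unchanged. This shows that the group at this one position can by itself shift the number by a large step, which compound 2 and compound 3 could not show, as each also carries a different group on the amide-type nitrogen. Nothing available here accounts for the size of this step.

The change also brings in a ring nitrogen and replaces methoxy with hydroxy in a single move, so the compounds shown do not separate these two parts; pyridin-2-yl without the hydroxy group and 5-methoxypyridin-2-yl would each carry only one of them. From the compounds shown here alone, it also remains open whether 5-hydroxypyridin-2-yl would give a similar step alongside another group on the amide-type nitrogen, such as the 4-fluoro-3-methylphenyl of compound 3.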